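The source may hold more compounds than are shown below. What is called first, only, known or untested is meant among the compounds shown, and "the series" means these compounds.

Measured compounds in a functional assay on BGC-823 cells (Homo sapiens) for antiproliferative activity, read by MTT assay, tested at 5 uM; a higher number here means a stronger effect of the compound at the concentration tested, a lower number a weaker effect:
- compound 1, `COc1ccc(OC)c(C2OC(c3cc(OC)c(OC)c(OC)c3)=NN2C(C)=O)c1`, gives 18.2%
- compound 2, `COc1cc(C2=NN(C(C)=O)C(c3ccc(Cl)c(Cl)c3)O2)cc(OC)c1OC`, gives 3.1%
- compound 3, `COc1cc(C2=NN(C(C)=O)C(c3ccccc3F)O2)cc(OC)c1OC`, gives 32.8%

Compound 3 stands highest of the three numbers in this assay. Its nearest neighbour is compound 1, where the change was a number 14.6 percentage points higher from compound 1 to compound 3 (beyond the scatter); the furthest is compound 2, where the change was a number 29.7 percentage points higher from compound 2 to compound 3 (beyond the scatter). Between compound 1 and compound 2 the change was a number 15.1 percentage points lower from compound 1 to compound 2 (beyond the scatter).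

Compound 4, `COc1cc(C2=NN(C(C)=O)C(c3ccc(Cl)c([N+](=O)[O-])c3)O2)cc(OC)c1OC`, differs from compound 3 in one place: 4-chloro-3-nitrophenyl in place of 2-fluorophenyl on a saturated ring carbon. The step from compound 2 to compound 3 bears most on this, since compound 2 carries a 3,4-dichlorophenyl on the same saturated ring carbon and compound 4 carries a 4-chloro-3-nitrophenyl there; that step was a number 29.7 percentage points higher from compound 2 to compound 3 (beyond the scatter). The step from compound 1 to compound 3 points the same way. A fall beyond the scatter is therefore expected in this assay, with the expected step being a number 22.8 percentage points lower from compound 3 to compound 4 (beyond the scatter). Compound 4 is expected to give about 10%, within a range from 0% to 25%.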

Compound 4, a percentage reported as inhibition, at one concentration (the size of the read-out at that concentration, not a potency): 0%
Compound 4: the middle estimate sits 10 percentage points above what was measured; the measured number falls inside the stated range.
By their numbers in this assay, from the lowest: compounds 4 and 2 (each within the scatter of the next); then compound 1; then compound 3.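

Placing the 4-chloro-3-nitrophenyl on the saturated ring carbon in this assay gives a number 32.8 percentage points lower from compound 3 to compound 4 (beyond the scatter) and, against the 2,5-dimethoxyphenyl, a number 18.2 percentage points lower from compound 1 to compound 4 (beyond the scatter) as well, so this position can lose the whole read-out seen with the 2-fluorophenyl. Swapping chloro for nitro on the aromatic carbon gives a number 3.1 percentage points lower from compound 2 to compound 4 (within the scatter) and thus leaves the read-out where the 3,4-dichlorophenyl had it, so among the compounds shown both phenyl groups carrying two substituents with a 4-chloro sit at the low end. Nothing measured here explains this fall.

Going by these compounds, whether a single chloro or a single nitro on the phenyl would be enough for the loss remains open. So does how an amine or a carboxylic acid on that phenyl would fare at this position.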